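The source may hold more compounds than are shown below. What is called first, only, known or untested is meant among the compounds shown, and "the series" means these compounds.

Measured in a functional assay on CEM-SS cells (Homo sapiens) for cytotoxicity; a lower number here means a stronger inhibitor, a higher number a weaker inhibitor:
- compound 1 `Fc1ccc(Cn2c(Cl)nc3cc(Cl)c(Cl)cc32)cc1`: > 100000 nM (a limit)
- compound 2 `O=[N+]([O-])c1ccc(Cn2c(Br)nc3cc(Cl)c(Cl)cc32)cc1`: > 100000 nM (a limit)

Compound 2 has no exact number, only the limit > 100000 nM. Both measured compounds sit there: the limit of > 100000 nM in this assay, at which 2 of the 2 values shown sit. Compound 3 `Fc1ccc(Cn2c(Br)nc3cc(Cl)c(Cl)cc32)cc1` carries fluoro in place of nitro on an aromatic carbon, para to a large group: fluoro in place of nitro on an aromatic carbon. Among the measured compounds shown here, no step between measured compounds is available, so no change beyond the scatter is expected in this assay, in either direction. The estimated a number no higher from compound 2 to compound 3 (the limit leaves the size open) is expected to stay within the scatter. For compound 3 the expected value is 100000 nM, with an estimated range of 30000 nM to 200000 nM.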

Compound 3, half-maximal inhibitory concentration: > 100000 nM
Compound 3 gave a limit, no number; the forecaster's own chance of this, stated with the estimate: 80%; the middle value lies on the limit itself.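

Among the compounds shown here, no step from compound 1 or compound 2 to compound 3 can be read in this assay; all three values are limits: the limit of > 100000 nM in this assay, at which 3 of the 3 values shown sit.
The compounds shown leave open how fluoro and nitro, or bromo and chloro, compare in this assay as exact numbers.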